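The source may report more compounds than this note shows. Statements on the series, on what has been measured and on what is new or still open speak of the compounds shown alone.

The measured compounds, with their readings in an assay for inhibition of methylcytosine dioxygenase TET2 (Homo sapiens), read by mass spectrometry, with stated times of 30 min and 1 h; a lower number here means a stronger inhibitor, a higher number a weaker inhibitor:

compound 1, `O=S(=O)(O)c1ccc(F)c2ncc(I)cc12`: 2300 nM
compound 2, `CCOS(=O)(=O)c1ccc(F)c2ncc(I)cc12`: > 200000 nM, which is a limit of the assay and not a number
compound 3, `CC(C)OS(=O)(=O)c1ccc(F)c2ncc(I)cc12`: > 200000 nM, which is likewise a limit of the assay

Compound 1 is the only one of the three with a measured number; the other two readings sit at the limit of > 200000 nM in this assay, at which 2 of the 3 values shown sit. Both measured steps change the group on the sulfonyl sulfur of compound 1, replacing the hydrogen on its oxygen with an alkyl group: an at least 86-fold higher number from compound 1 to compound 2 (1.93 log units; beyond the scatter) and an at least 86-fold higher number from compound 1 to compound 3 (1.93 log units; beyond the scatter). Between the two alkyl compounds, a step that the two limits leave unreadable from compound 2 to compound 3.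

Compound 4, `O=S(=O)(Nc1ccccc1)c1ccc(F)c2ncc(I)cc12`, has not yet been measured. It differs from compound 1 in one place: anilino in place of hydroxy on a sulfonyl sulfur. This change also alters the group on the sulfonyl sulfur, and the two measured steps that did so were both large losses of inhibition. The step to compound 4 is therefore expected to point the same way, toward a higher number, although its size is uncertain since the entering group is not an alkyl on oxygen. The estimated step is a 13-fold higher number from compound 1 to compound 4 (1.12 log units; beyond the scatter). Compound 4 is estimated at 30000 nM, with a range from 4000 nM to 200000 nM.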

Compound 4, half-maximal inhibitory concentration: 23900 nM
For compound 4 the middle estimate is 1.3-fold (0.10 log units) above the measured one; low and high end bracket the measured number.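

In this assay, anilino is the only replacement for hydroxy on the sulfonyl sulfur shown here that still gives a readable number, although it costs inhibition, with a 10-fold higher number from compound 1 to compound 4 (1.02 log units; beyond the scatter). Against the alkoxy groups on the same sulfur, anilino does better, with an at least 8.3-fold lower number from compound 3 to compound 4 (0.92 log units; beyond the scatter) and an at least 8.3-fold lower number from compound 2 to compound 4 (0.92 log units; beyond the scatter), so at this position the size of the loss depends on which group enters, and a replacement with a six-membered aromatic ring does not abolish inhibition in this assay. These two gains are only minimum sizes, and the step between the two alkoxy compounds cannot be read, because compound 2 and compound 3 each carry a limit and not a number: the limit of > 200000 nM in this assay, at which 2 of the 4 values shown sit.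

The compounds shown do not separate the contribution of the aromatic ring of anilino from that of its nitrogen, which a plain amino group or a benzylamino group on the sulfonyl sulfur would help to do. Going by these compounds, it also remains open whether any group on this sulfur, such as a methylamino group, can match the hydroxy of compound 1.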